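A few compounds are considered here, and "the series" means these few. Any claim that something is new, unique, unknown or untested is made for them only; others in the source may bear on it.

Three compounds share one core and differ only in the amide that closes a short chain. Compound 1 `O=C(CCn1cnc2cc(-c3noc(CCC4CCCCC4)n3)ccc21)N1CCCC1` is one of them. In a toxicity assay on HepG2 2.2.15 cells (Homo sapiens) for cytotoxicity, read by CCK-8 assay, with a stated time of 72 h (a higher number here means that more compound is tolerated, a lower number that less compound is tolerated), compound 1 reaches only a limit of the assay, > 20000 nM. Compound 2 `O=C(CCn1cnc2cc(-c3noc(CCC4CCCC4)n3)ccc21)N1CCCCC1` carries piperidin-1-yl on the carbonyl carbon. In this assay compound 2 also reports a limit, > 20000 nM. Compound 3 `O=C(CCn1cnc2cc(-c3noc(CCC4CCCC4)n3)ccc21)N1CCOCC1` carries morpholin-4-yl in that place. In this assay compound 3 likewise reports a limit, > 20000 nM. The step that the two limits leave unreadable from compound 2 to compound 3 cannot be read, as both of its ends sit at the limit of > 20000 nM in this assay, at which 3 of the 3 values shown sit. Compound 3 therefore stands where every measured compound stands: at a limit, with no number that would rank it against the others.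

Compound 4 `O=C(CCn1cnc2cc(-c3noc(CCC4CCCC4)n3)ccc21)NC1CCCCC1` differs from compound 3 by cyclohexylamino in place of morpholin-4-yl on a carbonyl carbon. Going by the values given here, no measured step touches this change, and the one step that is available is unreadable. The estimated step that the limit leaves unreadable from compound 3 to compound 4 is expected to be none beyond the scatter, with a limit the most likely outcome. For compound 4 the estimate in this assay is 30000 nM, between 12000 nM and 80000 nM.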

Compound 4, half-maximal cytotoxic concentration: > 20000 nM
Compound 4: a limit, no number; the forecaster's own chance of this, stated with the estimate: 80%; the middle value lies beyond the limit too.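

Compound 4 also reports only a limit, > 20000 nM, so neither step reaching it, from compound 2 or from compound 3, can be read: the limit of > 20000 nM in this assay, at which 4 of the 4 values shown sit. The compounds shown leave open how these four compounds rank in this assay and at what concentration, if any, each becomes toxic to the cells.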